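This account rests on a few compounds, and the source may have more. Where it says the series, first, only, none or still open, it means among the compounds named here.

Measured so far in a functional assay on A549 cells (Homo sapiens) for inhibition, read by MTT assay, with a stated time of 48 h; a higher number here means a weaker inhibitor, a lower number a stronger inhibitor: compound 1 `COc1ccc(N(C)c2nc(C)nc3ccccc23)cc1OCCN` gives 122 nM; compound 2 `COc1ccc(N(C)c2nc(C)nc3ccccc23)cc1C(=O)OCCCC[Se]C#N` gives 155 nM.

Compound 2 holds the higher of the two numbers, but the gap is only a 1.3-fold higher number from compound 1 to compound 2 (0.10 log units; within the scatter), so the two stand within the scatter of each other. Compound 3 `COc1ccc(N(C)c2nc(C)nc3ccccc23)cc1OCCCC[Se]C#N` differs from compound 2 by a group of 8 heavy atoms (5 carbon, 1 nitrogen, 1 oxygen, 1 selenium; no ring) in place of a group of 10 heavy atoms (6 carbon, 1 nitrogen, 2 oxygen, 1 selenium; no ring), on an aromatic carbon. Within the data shown here, the only measured step that bears on this position is a 1.3-fold higher number from compound 1 to compound 2 (0.10 log units; within the scatter), and because a 1.3-fold higher number from compound 1 to compound 2 (0.10 log units; within the scatter) stayed within the scatter, no step beyond the scatter is expected here, a 1.1-fold lower number from compound 2 to compound 3 (0.04 log units; within the scatter). Compound 3 is therefore estimated at 140 nM, with an expected range of 60 nM to 350 nM.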

Compound 3, half-maximal inhibitory concentration: 1200 nM
Beside the measured number, compound 3's estimate is 8.6-fold (0.93 log units) below it; the measured number lies above the stated range.
By their numbers in this assay, from the lowest: compounds 1 and 2 (each within the scatter of the next); then compound 3.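

On the aromatic carbon ortho to a methoxy group, removing the carbonyl link while keeping the chain ending in selenium and nitrile gives a 7.7-fold higher number from compound 2 to compound 3 (0.89 log units; beyond the scatter) in this assay, so the earlier agreement did not mean that this position accepts any such group. With the oxygen link held fixed, replacing the terminal nitrogen with the chain ending in selenium and nitrile gives a 9.8-fold higher number from compound 1 to compound 3 (0.99 log units; beyond the scatter), so the end of the chain also counts. No measurement here gives a cause for either step.

Still open, on these data alone, is whether an amide link, a shorter chain or sulfur in place of selenium would keep the number of compound 2.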